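A few compounds are considered here, and "the series" means these few. Any claim that something is new, unique, unknown or untested is made for them only; others in the source may bear on it.

Four compounds are built on two closely related cores. Compound 3 `O[C@H](c1ccccn1)[C@]1(c2cc(C(F)(F)F)ccn2)C[C@@H](O)C1` and compound 1 `C[C@]1(O)C[C@@](c2cc(C(F)(F)F)ccn2)([C@H](O)c2ccccn2)C1` share one core, while compound 2 `O[C@H](c1ccccn1)[C@]1(c2ccnc(C(F)(F)F)c2)C[C@@H](O)C1` and compound 4 `C[C@]1(O)C[C@@](c2ccnc(C(F)(F)F)c2)([C@H](O)c2ccccn2)C1` share the other. The two cores have the same atoms joined differently, and the difference between them is not broken down here.

Three of the four have been measured in an ADME assay on liver for metabolic stability, with Liver microsome (Rattus norvegicus) as the target, read by LC-MS, using microsomes, with a stated time of 5 h; on this read-out higher numbers stand for fast clearance and lower numbers for slow clearance. Compound 3 gives 50 mL/min/kg, compound 1 gives 117 mL/min/kg, and compound 2 gives 200 mL/min/kg. Compound 2 stands highest of the three; its gap to compound 1 lies within the scatter, while its gap to compound 3 lies beyond it.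

Within the first core the one change is methyl in place of hydrogen on a saturated ring carbon, and it made a 2.3-fold higher number from compound 3 to compound 1 (0.37 log units; beyond the scatter). The change that turns compound 2 into compound 4 is methyl in place of hydrogen on a saturated ring carbon, and since its place is described in the same words, it is the same change, now made on the other core. Compound 4 has not yet been measured in this assay.

The expectation for compound 4 rests on that single precedent, the step of a 2.3-fold higher number from compound 3 to compound 1 (0.37 log units; beyond the scatter). On that basis compound 4 is expected to show a step of about the same size, a 1.8-fold higher number from compound 2 to compound 4 (0.24 log units; within the scatter). The precedent is one pair on a different core. The range is kept wide, and a starting point as high as compound 2 leaves room for this assay to report only a limit. Compound 4 is estimated at 350 mL/min/kg, between 170 mL/min/kg and 700 mL/min/kg.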

Compound 4, clearance: 50 mL/min/kg
Compound 4: middle estimate off by 7.0-fold (0.85 log units), on the high side; measured number outside the range, below it.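

In this assay the methyl in place of hydrogen on a saturated ring carbon gave a 4.0-fold lower number from compound 2 to compound 4 (0.60 log units; beyond the scatter), and this step runs opposite to the earlier one, so the change did not carry over from one core to the other: the same change on two cores in this assay, a 2.3-fold higher number (0.37 log units; beyond the scatter) from compound 3 to compound 1 and a 4.0-fold lower number (0.60 log units; beyond the scatter) from compound 2 to compound 4, 9.4-fold (0.97 log units) apart, beyond the scatter of two such steps

Across these four compounds, then, the step seen on one core predicted neither the size nor the direction of the step on the other, and the outcome of adding this methyl depended on the core that carried it. This does not show which feature of the two cores sets the steps apart, nor what the same change would do on a third core, and each step rests on a single pair of compounds.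

The compounds shown leave open whether the opposite steps belong to the methyl alone or would also appear with another group on that saturated ring carbon, such as an ethyl group, a fluorine atom or an amine. They also leave open whether the two cores would still part in this way if the trifluoromethyl group gave way to a nitrile.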